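The source may report more compounds than this note shows. Statements on the series, on what has been measured and on what is new or still open speak of the compounds shown alone.

Compound 1 `CSc1ncnc2c1c(-c1ccsc1)cn2[C@@H]1O[C@H](CO)[C@@H](O)[C@H]1O`, compound 2 `CNc1ncnc2c1c(-c1ccoc1)cn2[C@@H]1O[C@H](CO)[C@@H](O)[C@H]1O` and compound 3 `Cc1ncnc2c1c(-c1ccoc1)cn2[C@@H]1O[C@H](CO)[C@@H](O)[C@H]1O` share one core and were all tested in a functional assay on HeLa S3 cells (Homo sapiens) for antiproliferative activity, read by XTT assay, with a stated time of 72 h; a higher number here means a weaker inhibitor, a lower number a stronger inhibitor. Compound 1 gives > 20000 nM, which is a limit and not a number. Compound 2 gives > 20000 nM, again a limit. Compound 3 gives > 20000 nM, also a limit. Compound 3 therefore stands at the limit of > 20000 nM in this assay, at which 3 of the 3 values shown sit, and no number places it relative to the other two.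

The next compound, compound 4 `Cc1ncnc2c1c(-c1ccsc1)cn2[C@@H]1O[C@H](CO)[C@@H](O)[C@H]1O`, differs from compound 3 in one place: thiophen-3-yl in place of furan-3-yl on an aromatic carbon. Going by the values given here, no measured pair isolates this swap. Among the compounds with values here, the only measured step, a step that the two limits leave unreadable from compound 2 to compound 3, concerns a different place, and its size cannot be read. Thiophen-3-yl is already present in compound 1, whose reading of > 20000 nM is a limit as well. So the only compound carrying the incoming group offers no sign of measurable activity, although it differs elsewhere. On that basis, the estimated step in this assay, a number no higher from compound 3 to compound 4 (the limit leaves the size open), is not expected to go beyond the scatter in either direction. For compound 4 the expected value is 20000 nM, with an estimated range from 5000 nM to 40000 nM. The most likely outcome is another reading reported only as a limit.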

Compound 4, half-maximal inhibitory concentration: 14300 nM
Beside the measured number, compound 4's estimate is 1.4-fold (0.15 log units) above it; measured number inside the range.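

In this assay compound 4 is the first of the compounds shown to give a number and not a limit: the limit of > 20000 nM in this assay, at which 3 of the 4 values shown sit. Putting thiophen-3-yl in place of furan-3-yl on this aromatic carbon gives an at least 1.3-fold lower number from compound 3 to compound 4 (0.14 log units; that floor lies within the scatter), and only this floor can be read, so the swap is compatible with a real gain but does not prove one. Putting methyl in place of methylsulfanyl gives an at least 1.3-fold lower number from compound 1 to compound 4 (0.14 log units; that floor lies within the scatter), which again proves no gain, yet compound 1 carries the same thiophen-3-yl and still reads only as a limit, so that group alone does not ensure a measurable value.

From the compounds shown here alone, how large either step really is stays open, and so does whether the activity of compound 4 depends on thiophen-3-yl and methyl occurring together. The compounds shown also do not tell how a phenyl ring at this position, or an ethyl chain in place of the methyl, would read.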